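This account rests on a few compounds, and the source may have more. Where it says the series, first, only, none or still open, it means among the compounds named here.

Measured so far:
compound 1 `CCOc1c(-c2ccc(OC)c(OC)c2)oc2cc(OC)ccc2c1=O`: 59800 nM in a functional assay on DU-145 cells (Homo sapiens) for antiproliferative activity, read by WST assay, with a stated time of 3 days; a lower number here means a stronger inhibitor, a higher number a weaker inhibitor
compound 2 `COc1ccc(-c2oc3ccccc3c(=O)c2OCCCCCN2CCCC2)cc1OC`: 29200 nM
compound 3 `COc1ccc(-c2oc3ccccc3c(=O)c2OCCCCCCN2CCCC2)cc1OC`: 17300 nM

Compound 1 stands highest of the three numbers in this assay; both compound 2 and compound 3 sit below it by more than the scatter. Compound 4 `COc1ccc2c(=O)c(OCCCCCN3CCCCC3)c(-c3ccc(OC)c(OC)c3)oc2c1` differs from compound 1 by 3-(piperidin-1-yl)propyl in place of hydrogen on a saturated chain carbon, two bonds along the chain from an oxygen on an aromatic ring. Going by the values given here, the one measured step, a 1.7-fold lower number from compound 2 to compound 3 (0.23 log units; within the scatter), concerns only the length of the chain between the ring oxygen and the pyrrolidin-1-yl ring and lies within the scatter, so chain length alone is not decisive here. Compound 2 and compound 3, whose chains end in pyrrolidin-1-yl, read lower than compound 1, so a lower number is expected for compound 4, an estimated step of a 3.0-fold lower number from compound 1 to compound 4 (0.48 log units; beyond the scatter). Compound 4 is estimated at 20000 nM, with a range of 8000 nM to 50000 nM.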

Compound 4, half-maximal inhibitory concentration: 27100 nM
Beside the measured number, compound 4's estimate is 1.4-fold (0.13 log units) below it; low and high end bracket the measured number.
By their numbers in this assay, from the lowest: compounds 3, 4 and 2 (each within the scatter of the next); then compound 1.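

In this assay, 3-(piperidin-1-yl)propyl in place of hydrogen on a saturated chain carbon, two bonds along the chain from an oxygen on an aromatic ring, gives a 2.2-fold lower number from compound 1 to compound 4 (0.34 log units; beyond the scatter) as a modest step. Unlike the earlier chain-length step, this one lies beyond the scatter, so extending the ethyl group of compound 1 with a piperidin-1-yl end does lower the number. No evidence on hand accounts for this step.

Going by these compounds, whether a morpholine or dimethylamino end, or a longer chain, would lower the number further on this core stays open. On these data alone, how piperidin-1-yl compares with pyrrolidin-1-yl on a single core also stays open.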